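A few compounds are considered here, and "the series" means these few. Any claim that something is new, unique, unknown or untested is made for them only; others in the source may bear on it.

Measured so far:
- compound 1 `O=C(/C=C/c1ccc([N+](=O)[O-])cc1)Nc1cc(Sc2ncn[nH]2)c(O)c2ccccc12` gives > 100000 nM in a functional assay on PC-3 cells (Homo sapiens) for antiproliferative activity, read by MTT assay, with a stated time of 48 h (a higher number here means a weaker inhibitor, a lower number a stronger inhibitor), which is a limit of the assay.
- compound 2 `Cc1nnc(Sc2cc(NC(=O)c3ccc(Cl)cc3)c3ccccc3c2O)s1` gives 49500 nM in this assay.
- compound 3 `O=C(/C=C/c1ccccc1)Nc1cc(Sc2ncn[nH]2)c(O)c2ccccc12` gives > 100000 nM in this assay, again a limit.

Among the measured compounds shown here, compound 2 is the only member of the series with a numerical reading; the other two sit at the limit of > 100000 nM in this assay, at which 2 of the 3 values shown sit. For the measured compounds named here, the sole step between measured compounds, a step that the two limits leave unreadable from compound 1 to compound 3, runs between two limits and its size cannot be read.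

Compound 4 `Cn1nnnc1Sc1cc(NC(=O)c2ccc(Cl)cc2)c2ccccc2c1O` differs from compound 2 by 1-methyl-1H-tetrazol-5-yl in place of 5-methyl-1,3,4-thiadiazol-2-yl on a sulfur. Going by the values given here, no measured step touches the group on this sulfur: the one step available concerns a substituent on the cinnamamide ring and is unreadable. There is therefore no basis for expecting a shift beyond the scatter; the step from compound 2 to compound 4 is estimated as a 1.0-fold higher number from compound 2 to compound 4 (0.00 log units; within the scatter). In this assay compound 4 is expected at about 50000 nM, with a range from 15000 nM to 150000 nM, and a fair chance that only a limit is reported.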

Compound 4, half-maximal inhibitory concentration: > 100000 nM
Compound 4: no number, only a limit (the forecaster's own chance of this, stated with the estimate: 35%); middle value at least 2.0-fold (0.30 log units) from the limit.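

In this assay, among the compounds shown here, the group on the sulfur is the first place where a change yields a readable step: 1-methyl-1H-tetrazol-5-yl in place of 5-methyl-1,3,4-thiadiazol-2-yl gives an at least 2.0-fold higher number from compound 2 to compound 4 (0.30 log units; that floor lies within the scatter). For the compounds shown here, the true size of this step stays open above that floor, and the reading of compound 2 remains the only number. The exchange of one five-membered aromatic ring for the other on this sulfur therefore brings no new numerical reading, and the values now crowd at one end of the range: the limit of > 100000 nM in this assay, at which 3 of the 4 values shown sit.

On these data alone, whether the step from compound 2 to compound 4 is larger than the scatter remains open. Also open, as far as these compounds go, is how the series responds on this sulfur to a group without an aromatic ring, such as a longer alkyl chain or a chain ending in a carboxylic acid or an amine.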